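Swapping the five-membered ring on an amide: an expectation

A few compounds are considered here, and "the series" means these few. Any claim that something is new, unique, unknown or untested is made for them only; others in the source may bear on it.

Among the measured compounds shown here, compound 1, with the structure `COc1cc2c(Oc3ccc(NC(=O)c4cc(-c5ccc(F)cc5)on4)cc3)ccnc2cc1OCCCN1CCC(C)CC1`, is one of two compounds measured in a functional assay on HT-29 cells (Homo sapiens) for antiproliferative activity, read by MTT assay, with a stated time of 72 h; on this read-out higher numbers stand for weaker inhibition and lower numbers for stronger inhibition. In this assay compound 1 gives 24600 nM, the only plain number among the two results shown. Compound 2, with the structure `COc1cc2nccc(Oc3ccc(NC(=O)c4ncc(-c5ccc(F)cc5)o4)cc3)c2cc1OC`, shares the same amide-linked framework but differs in several places. In this assay compound 2 reaches only a limit of the assay, > 100000 nM. That result stands as the limit of > 100000 nM in this assay, at which 1 of the 2 values shown sits.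

Compound 3, with the structure `COc1cc2c(Oc3ccc(NC(=O)c4nc(-c5ccc(F)cc5)no4)cc3)ccnc2cc1OCCCN1CCC(C)CC1`, has not yet been measured in this assay. It differs from compound 1 in one place: 3-(4-fluorophenyl)-1,2,4-oxadiazol-5-yl in place of 5-(4-fluorophenyl)-1,2-oxazol-3-yl on a carbonyl carbon. For the measured compounds named here, no pair of measured compounds differing in just one place is available to show how such a change moves the result, so nothing measured here anchors the direction. The expectation is therefore cautious: the step in this assay is expected to be a 1.2-fold higher number from compound 1 to compound 3 (0.09 log units; within the scatter), within the usual scatter or a little towards weaker inhibition. Compound 3 is accordingly estimated at 30000 nM, with a likely range from 10000 nM to 100000 nM.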

Compound 3, half-maximal inhibitory concentration: 6380 nM
Beside the measured number, compound 3's estimate is 4.7-fold (0.67 log units) above it; measured number outside the range, below it.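

In this assay, this position on the carbonyl carbon now has its first measured step, and it lies beyond the usual scatter: a 3.9-fold lower number from compound 1 to compound 3 (0.59 log units; beyond the scatter). The rest of the molecule stays the same, including the 4-fluorophenyl group, so the step belongs to the exchange of 5-(4-fluorophenyl)-1,2-oxazol-3-yl for 3-(4-fluorophenyl)-1,2,4-oxadiazol-5-yl, in which the five-membered ring gains a nitrogen and loses a carbon, and the step points towards stronger inhibition. The result therefore shows that this ring is not an interchangeable spacer on the amide, although nothing given here bears on why the number moves.

From the compounds shown here alone, this is a single pair in a single assay, so it sets no general rule for five-membered rings at this position, and it is unknown whether the same step would appear with a different side chain on the shared core. Also open, going by these compounds, is how a thiazole or a 1,3,4-oxadiazole would behave on the same carbonyl carbon, and whether a chlorine or a methoxy group in place of the fluorine would shift the result of compound 3.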